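A few compounds are considered here, and "the series" means these few. Any claim that something is new, unique, unknown or untested is made for them only; others in the source may bear on it.

Three close relatives share one core, differing only in the aryl group attached to the five-membered ring. Compound 1 `COc1cc(/C=C/C(=O)C(=Cc2cn(-c3ccccc3)nc2-c2ccc([N+](=O)[O-])cc2)C(=O)/C=C/c2ccc(O)c(OC)c2)ccc1O` carries a 4-nitrophenyl there, compound 2 `COc1cc(/C=C/C(=O)C(=Cc2cn(-c3ccccc3)nc2-c2ccccc2O)C(=O)/C=C/c2ccc(O)c(OC)c2)ccc1O` a 2-hydroxyphenyl, and compound 3 `COc1cc(/C=C/C(=O)C(=Cc2cn(-c3ccccc3)nc2-c2cccc([N+](=O)[O-])c2)C(=O)/C=C/c2ccc(O)c(OC)c2)ccc1O` a 3-nitrophenyl. In a functional assay on MCF7 cells (Homo sapiens) for antiproliferative activity, read by MTT assay, with a stated time of 24 h, tested at 0.1 ug/mL (on this read-out lower numbers stand for a stronger effect and higher numbers for a weaker effect at the one concentration tested), compound 1 gives 92%, compound 2 gives 91%, and compound 3 gives 85%. Compound 3 holds the lowest of the three numbers, but the gap a number 7 percentage points lower from compound 1 to compound 3 (within the scatter) and the gap a number 6 percentage points lower from compound 2 to compound 3 (within the scatter) both lie within the scatter, as does a number 1 percentage points lower from compound 1 to compound 2 (within the scatter), so the three compounds cannot be told apart on this read-out.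

Compound 4 `COc1cc(/C=C/C(=O)C(=Cc2cn(-c3ccccc3)nc2-c2ccc(Cl)cc2)C(=O)/C=C/c2ccc(O)c(OC)c2)ccc1O` takes the next step: 4-chlorophenyl in place of 3-nitrophenyl on an aromatic carbon. Going by the values given here, no measured pair contains a 4-chlorophenyl, so no step speaks directly to this change. What the measured steps do show is that exchanging one aryl group for another at this position, whether nitrophenyl for hydroxyphenyl or a shift of the nitro group, moved this assay by amounts no larger than the scatter. On that basis the step to compound 4 is expected to be small as well, a number 3 percentage points higher from compound 3 to compound 4 (within the scatter), with no direction beyond the scatter. The estimate for compound 4 in this assay is 88%, within a range from 78% to 98%.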

Compound 4, a percentage reported as activity, at one concentration (the size of the read-out at that concentration, not a potency): 72%
Beside the measured number, compound 4's estimate is 16 percentage points above it, outside the stated range (below it).
By their numbers in this assay, from the lowest: compound 4; then compounds 3, 2 and 1 (each within the scatter of the next).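

In this assay this position turns out not to be indifferent to its aryl group, since the 4-chlorophenyl of compound 4 gives steps beyond the scatter against all three earlier compounds: a number 13 percentage points lower from compound 3 to compound 4 (beyond the scatter) and a number 19 percentage points lower from compound 2 to compound 4 (beyond the scatter) and also a number 20 percentage points lower from compound 1 to compound 4 (beyond the scatter) as the last of the three. That last step is the simplest to read, as the phenyl stays in place and only chloro in place of nitro changes, so swapping this one group is enough to separate compound 4 from compound 1, and compound 4 alone stands as the most active of the four at the one concentration tested. Why the chloro compound stands apart cannot be said, as no measurement on hand bears on the cause.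

On these data alone, whether a bromo group or an amine in place of the chloro would keep, deepen or lose this step remains open, as does whether chloro would do the same on another carbon of the phenyl ring. As far as these compounds go, a reading at one concentration gives the size of an effect and not a potency, so how compound 4 would compare with the others across a range of concentrations also remains unknown.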